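Swapping an amide substituent on a lignan-like core

The compounds below may be only part of what the source reports. "The series", "measured", "known", "first", "only" and "open" are said of these compounds alone.

Measured so far:
compound 1 `COC(=O)[C@@H]1CCCN1C(=O)CCC(=O)Oc1ccc(C[C@H]2C(=O)OC[C@@H]2Cc2ccc(OC)c(OC)c2)cc1OC`: 145000 nM
compound 2 `COc1ccc(C[C@H]2COC(=O)[C@@H]2Cc2ccc(OCC(=O)Nc3ccc(C)cc3)c(OC)c2)cc1OC`: 228000 nM
compound 3 `COc1ccc(-n2cc(COc3ccc(C[C@H]4C(=O)OC[C@@H]4Cc4ccc(OC)c(OC)c4)cc3OC)nn2)cc1`: >= 600000 nM

In an ADME assay on HeLa cells (Homo sapiens) for cytotoxicity, read by MTT assay (on this read-out lower numbers stand for stronger inhibition and higher numbers for weaker inhibition), compound 2 gives 228000 nM, the higher of the two plain numbers, while compound 1 sits within the usual scatter of it at 145000 nM. For compound 3 the assay reports only a limit, >= 600000 nM, and not a number, as the limit of >= 600000 nM in this assay, at which 1 of the 3 values shown sits, records.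

Compound 4 `COc1ccc(C[C@H]2COC(=O)[C@@H]2Cc2ccc(OCC(=O)N3CCOCC3)c(OC)c2)cc1OC` has not yet been measured. It differs from compound 2 in one place (morpholin-4-yl in place of (4-methylphenyl)amino on a carbonyl carbon). Within the data shown here, no measured pair here changes this position, so nothing in the data points to a step in either direction. In this assay the step from compound 2 to compound 4 is expected to stay within the scatter, a 1.1-fold higher number from compound 2 to compound 4 (0.04 log units; within the scatter). Compound 4 is therefore estimated at 250000 nM, between 100000 nM and 600000 nM.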

Compound 4, half-maximal inhibitory concentration: >= 600000 nM
Compound 4: only a limit was reported (the forecaster's own chance of this, stated with the estimate: 25%); at least 2.4-fold (0.38 log units) between middle value and limit.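

Morpholin-4-yl in place of (4-methylphenyl)amino on a carbonyl carbon gives, in this assay, an at least 2.6-fold higher number from compound 2 to compound 4 (0.42 log units; beyond the scatter). For compound 4 the figure is a limit and not a number: the limit of >= 600000 nM in this assay, at which 2 of the 4 values shown sit.

Among these compounds, this is the first measured pair that differs in one place, and it shows that this position responds to a change, here towards weaker inhibition.

The change removes the aromatic ring and the amide hydrogen and adds the morpholine oxygen all at once, and the compounds shown do not separate these. Also open, on these data alone, is how piperidin-1-yl or plain phenylamino on the same carbonyl carbon would read.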